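Swapping Halogens on the Aryl Hydrazone: Chloro to Iodo

This account rests on a few compounds, and the source may have more. Where it says the series, first, only, none or still open, it means among the compounds named here.

Measured compounds:
compound 1 `CCOC(=O)/C(CCCC(=O)O)=N\Nc1ccc(Br)cc1` gives 21000 nM
compound 2 `CCOC(=O)/C(CCCC(=O)O)=N\Nc1ccc([N+](=O)[O-])cc1` gives 179000 nM
compound 3 `CCOC(=O)/C(CCCC(=O)O)=N\Nc1cccc(Cl)c1` gives 20000 nM

These three share one core, an ester-bearing hydrazone carrying a short carboxylic acid chain, and differ only in the aromatic ring on the amine nitrogen. In an assay on isolated protein for inhibition of kynurenine--oxoglutarate transaminase 1 (Homo sapiens), read by HPLC, with a stated time of 20 min (a higher number here means a weaker inhibitor, a lower number a stronger inhibitor), compound 3 sits at the low end of the three numbers, but its gap to compound 1 lies within the scatter, so the two cannot be told apart; compound 2 stands well away from both, its number being the highest.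

Compound 4 `CCOC(=O)/C(CCCC(=O)O)=N\Nc1ccc(I)cc1` has not been measured. It differs from compound 3 by 4-iodophenyl in place of 3-chlorophenyl on an amine nitrogen. Two measured steps speak to this change. The step of a 1.1-fold lower number from compound 1 to compound 3 (0.02 log units; within the scatter) shows that moving from a 4-bromophenyl to a 3-chlorophenyl changed nothing beyond the scatter. The step of an 8.5-fold higher number from compound 1 to compound 2 (0.93 log units; beyond the scatter) shows that a nitro group in place of bromo raised the number by a modest amount. Since compound 4 keeps a halogen rather than introducing a nitro group, and since the halogen swap already seen was flat, the expected step of a 1.1-fold lower number from compound 3 to compound 4 (0.02 log units; within the scatter) is none beyond the scatter. Compound 4 is therefore estimated at 19000 nM, with a range from 8000 nM to 45000 nM.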

Compound 4, half-maximal inhibitory concentration: 34000 nM
Estimate against measurement, compound 4: 1.8-fold (0.25 log units) below, and the stated range covers the measured number.
By their numbers in this assay, from the lowest: compounds 3, 1 and 4 (each within the scatter of the next); then compound 2.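

In this assay, the series now holds a third halogen on the ring, and swapping it in stays within the scatter from either side: 4-iodophenyl in place of 3-chlorophenyl on an amine nitrogen gives a 1.7-fold higher number from compound 3 to compound 4 (0.23 log units; within the scatter), and replacing bromo with iodo gives a 1.6-fold higher number from compound 1 to compound 4 (0.21 log units; within the scatter), so the chloro, bromo and iodo compounds cannot be told apart here. Iodo in place of nitro on an aromatic carbon gives a 5.3-fold lower number from compound 2 to compound 4 (0.72 log units; beyond the scatter), which lies beyond the scatter, so compound 2 now stands apart from two different halogens at the same ring carbon and not from bromo alone. The data shown offer no measurement that would explain this split between the nitro compound and the three halogen compounds.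

Compound 3 carries a different halogen at a different ring place from the other two halogen compounds, so a 4-chlorophenyl group would be needed to separate the effect of the halogen from that of its place. From the compounds shown here alone, it also stays open whether an amine or a methoxy group on the ring would fall with the halogens or with the nitro compound, and whether a longer chain carrying the carboxylic acid would shift the whole series.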